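Replacing chloromethyl in compound 2 with prop-1-en-1-yl

The source may hold more compounds than are shown below. What is called first, only, known or untested is meant among the compounds shown, and "the series" means these compounds.

Measured in a functional assay on Rec1 cells (Homo sapiens) for inhibition, read by luminescence and CellTiter-Glo, with a stated time of 72 h; a lower number here means a stronger inhibitor, a higher number a weaker inhibitor:
- compound 1 `C=CC(=O)Nc1ccc(Cn2nc(-c3ccc(Oc4ccccc4)cc3)cc2C(=O)O)cc1`: > 60000 nM
- compound 2 `O=C(CCl)Nc1ccc(Cn2nc(-c3ccc(Oc4ccccc4)cc3)cc2CO)cc1`: 400 nM
- compound 3 `C/C=C/C(=O)Nc1cccc(Cn2nc(-c3ccc(Oc4ccccc4)cc3)cc2C(=O)O)c1`: 26000 nM

The value for compound 1 is a limit of the assay and not a number. That leaves two numbers, and compound 2 has the lower of them. Compound 3, the nearest, has a higher number, and the gap lies beyond the scatter.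

Compound 4 `C/C=C/C(=O)Nc1ccc(Cn2nc(-c3ccc(Oc4ccccc4)cc3)cc2CO)cc1` has prop-1-en-1-yl in place of chloromethyl on a carbonyl carbon. Within the data shown here, no measured pair isolates this change. Compound 3 also carries prop-1-en-1-yl on a carbonyl carbon, and its value of 26000 nM leads to the expectation of a weaker compound, though it differs from compound 4 elsewhere too. A moderate rise beyond the scatter is therefore expected, and the estimated step is a 7.5-fold higher number from compound 2 to compound 4 (0.88 log units; beyond the scatter). For compound 4, the estimated value in this assay is 3000 nM, with an expected range from 700 nM to 15000 nM.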

Compound 4, half-maximal inhibitory concentration: 12200 nM
Beside the measured number, compound 4's estimate is 4.1-fold (0.61 log units) below it; low and high end bracket the measured number.
By their numbers in this assay, from the lowest: compound 2; then compound 4; then compound 3. At a limit, above all of these: compound 1.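

In this assay, among these compounds, this is the first pair that differs in one place, so the effect of the exchange on a carbonyl carbon can now be read directly: prop-1-en-1-yl in place of chloromethyl gives a 31-fold higher number from compound 2 to compound 4 (1.48 log units; beyond the scatter). With the rest of the structure unchanged, the lower number goes with the chloromethyl group in this single pair, and the data do not tell why. The step lies between two true numbers, as only compound 1 stands at a limit, which is not a number: the limit of > 60000 nM in this assay, at which 1 of the 4 values shown sits.

From the compounds shown here alone, whether a bromomethyl group or a longer chain on this carbonyl carbon would stay nearer compound 2 or compound 4 remains open. Also open, going by these compounds, is whether the same exchange gives a step of similar size on a core carrying the carboxylic acid.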